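Benzyl amide in place of butyl amide: an expected small gain

The source may hold more compounds than are shown below. What is called first, only, known or untested is meant among the compounds shown, and "the series" means these compounds.

Compound 2 `CCCCNC(=O)C1CC(=O)c2cc(O)c(OC)cc2O1` holds the highest number of the three compounds in a functional assay on the whole organism for inhibition, with Rattus norvegicus as the target (on this read-out lower numbers stand for stronger inhibition and higher numbers for weaker inhibition), where compound 2 gives 66400 nM. Compound 1 `COc1cc2c(cc1O)CCC(C(=O)Nc1ccccc1)O2` gives 24900 nM and compound 3 `COc1cc2c(cc1O)CCC(C(=O)O)O2` gives 16800 nM. Among the compounds with values here, the only single-point step among the measured compounds, a 1.5-fold lower number from compound 1 to compound 3 (0.17 log units; within the scatter), concerns the amide end but not an exchange of chain for ring, so it does not bear directly on the present change. Compound 4 `COc1cc2c(cc1O)C(=O)CC(C(=O)NCc1ccccc1)O2` differs from compound 2 by phenyl in place of propyl on a saturated chain carbon bound to an amide-type nitrogen. Within the data shown here, what the data offer is only that compound 1, which carries a six-membered aromatic ring on its amide nitrogen, shows a lower number than compound 2 with its butyl amide, though the two also differ elsewhere. On that basis a modest step toward a lower number is expected, at the edge of the scatter, a 2.2-fold lower number from compound 2 to compound 4 (0.35 log units; beyond the scatter). Compound 4 is therefore estimated at 30000 nM, within a range from 12000 nM to 80000 nM.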

Compound 4, half-maximal inhibitory concentration: 119000 nM
Beside the measured number, compound 4's estimate is 4.0-fold (0.60 log units) below it; the whole stated range lies below it.
By their numbers in this assay, from the lowest: compounds 3 and 1 (each within the scatter of the next); then compounds 2 and 4 (each within the scatter of the next).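

In this assay the exchange of butyl for benzyl on the amide comes to a 1.8-fold higher number from compound 2 to compound 4 (0.25 log units; within the scatter) and so does not separate the two groups. Within the data shown here, this is the first direct reading of an open chain against a six-membered aromatic ring at this place, and the added ring brings no change that rises out of the scatter. The data shown give no explanation for this result.

What the compounds shown leave open is whether a group not among them, such as a phenethyl or a 2-(dimethylamino)ethyl on the amide nitrogen, would read apart from butyl and benzyl. The steps from compound 2 or compound 4 to compound 1 and compound 3 cannot be read, as those pairs differ in more than one place.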